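Benzimidazole-free note: N-substituent swap in isoxazole-ether acid series

The source may report more compounds than this note shows. Statements on the series, on what has been measured and on what is new or still open speak of the compounds shown alone.

Measured compounds:
compound 1 `CC(C)c1onc(-c2c(Cl)cccc2Cl)c1COc1ccc(-c2nc3ccc(C(=O)O)cc3n2CC2CC2)cc1`, an assay on isolated protein for agonist activity at Bile acid receptor (Homo sapiens), read by TR-FRET; on this read-out higher numbers stand for an effect only at larger amounts of compound and lower numbers for an effect already at smaller amounts: 29.1 nM
compound 2 `CC(C)c1onc(-c2c(Cl)cccc2Cl)c1COc1ccc(-c2nc3ccc(C(=O)O)cc3n2C2CCCC2)cc1`: "not determined" (no result reported)
compound 3 `CC(=O)C1CCC(Cn2c(-c3ccc(OCc4c(-c5c(Cl)cccc5Cl)noc4C(C)C)cc3)nc3ccc(C(=O)O)cc32)CC1`: "not determined" (no result reported)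

Among the compounds with values here, compound 3 stands without a single number in this assay; compound 2 likewise carries no number, so the only value in hand is that of compound 1, which in this assay gives 29.1 nM.

The step to compound 4 `CC(C)c1onc(-c2c(Cl)cccc2Cl)c1COc1ccc(-c2nc3ccc(C(=O)O)cc3n2Cc2ccc(F)cc2)cc1` is the change (4-fluorophenyl in place of 4-acetylcyclohexyl on a saturated chain carbon bound to an aromatic nitrogen). Within the data shown here, no step between two measured compounds is available for comparison. Since compound 3 itself has no value, neither the direction nor the size of the step from compound 3 to compound 4 in this assay can be read from the data. Among the measured compounds shown here, the only measured anchor is compound 1, which in this assay gives 29.1 nM.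

Compound 4 is expected to give about 35 nM in this assay, with a plausible range from 10 nM to 150 nM.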

Compound 4, half-maximal effective concentration: 105 nM
Compound 4: the middle estimate sits 3.0-fold (0.48 log units) below what was measured; the measured number falls inside the stated range.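

In this assay, 4-fluorophenyl in place of cyclopropyl on a saturated chain carbon bound to an aromatic nitrogen gives a 3.6-fold higher number from compound 1 to compound 4 (0.56 log units; beyond the scatter), so this position keeps activity with an aromatic ring of carbon only, though at a modest cost beyond the usual scatter. Steps to or from compound 2 and compound 3 cannot be read, as neither compound carries a number. Nothing in hand accounts for the higher number with this change.

As far as these compounds go, it remains open whether the fluorine contributes to this step, which a plain phenyl in place of 4-fluorophenyl would address. Also open, from the compounds shown here alone, is how the read-out responds to a longer chain between the aromatic nitrogen and the ring, or to an amine on that ring.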